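This account rests on a few compounds, and the source may have more. Where it says the series, first, only, none or still open, it means among the compounds named here.

Measured so far:
compound 1 `Cc1noc(C)c1-c1cnc(N)c(Oc2ccc(C(=O)Nc3cc(Cl)ccn3)cc2)n1` — > 100000 nM
compound 2 `Cn1cc(-c2cnc(N)c(Oc3ccc(C(=O)Nc4ccccc4Cl)cc3)n2)cn1` — 41400 nM
compound 3 `Cn1cc(-c2cnc(N)c(Oc3ccc(C(=O)Nc4cccc(Cl)n4)cc3)n2)cn1` — 48600 nM

In a functional assay on LoVo cells (Homo sapiens) for inhibition, read by MTT assay, with a stated time of 72 h (on this read-out lower numbers stand for stronger inhibition and higher numbers for weaker inhibition), compound 1 gives > 100000 nM, which is a limit of the assay and not a number. Compound 2 gives 41400 nM in this assay. Among the measured compounds shown here, compound 3 gives 48600 nM in this assay; among the two numbers it is the highest, and its nearest neighbour is compound 2, the only measured step being a 1.2-fold higher number from compound 2 to compound 3 (0.07 log units; within the scatter), so the two cannot be ordered.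

Compound 4 `Cn1cc(-c2cnc(N)c(Oc3ccc(C(=O)Nc4cc(Cl)ccn4)cc3)n2)cn1` is not yet measured. It differs from compound 3 by 4-chloropyridin-2-yl in place of 6-chloropyridin-2-yl on an amide-type nitrogen. For the measured compounds named here, no measured step moves the chlorine around the pyridine in this way. Going by the values given here, the one measured step on the amide substituent, a 1.2-fold higher number from compound 2 to compound 3 (0.07 log units; within the scatter), was within the scatter, and compound 1, which carries the same 4-chloropyridin-2-yl group on a different core, sits at the limit of > 100000 nM in this assay, at which 1 of the 3 values shown sits. Taken together, a step of no more than the scatter is expected, with a real chance that only a limit is reported; the expected step is a 1.4-fold higher number from compound 3 to compound 4 (0.16 log units; within the scatter). Compound 4 is estimated at 70000 nM in this assay, within a range from 25000 nM to 200000 nM.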

Compound 4, half-maximal inhibitory concentration: 26600 nM
Estimate against measurement, compound 4: 2.6-fold (0.42 log units) above; the measured number falls inside the stated range.
By their numbers in this assay, from the lowest: compounds 4, 2 and 3 (each within the scatter of the next). At a limit, above all of these: compound 1.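

Working notes on the series: the chlorine position on the pyridine now has a measured step in this assay, a 1.8-fold lower number from compound 3 to compound 4 (0.26 log units; within the scatter), and the exchange against the phenyl ring gives a 1.6-fold lower number from compound 2 to compound 4 (0.19 log units; within the scatter), so 2-chlorophenyl, 6-chloropyridin-2-yl and 4-chloropyridin-2-yl on the amide-type nitrogen cannot be ordered. Among the compounds shown here, the first step beyond the scatter lies away from the amide: with 4-chloropyridin-2-yl held fixed, 1-methyl-1H-pyrazol-4-yl in place of 3,5-dimethyl-1,2-oxazol-4-yl on an aromatic carbon gives an at least 3.7-fold lower number from compound 1 to compound 4 (0.57 log units; beyond the scatter). Compound 1 remains a limit of the assay and not a number, so the size of that step is bounded on one side only: the limit of > 100000 nM in this assay, at which 1 of the 4 values shown sits.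

Going by these compounds, it remains open whether any group on the amide-type nitrogen can move the number beyond the scatter, for instance a pyridin-2-yl carrying a methoxy group or a primary amine in place of the chlorine, or one carrying a carboxylic acid. On these data alone, it also remains open whether the step between 3,5-dimethyl-1,2-oxazol-4-yl and 1-methyl-1H-pyrazol-4-yl holds with other amide substituents, as it rests on this single pair.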